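The compounds below may be only part of what the source reports. "The series", "measured", "known", "first", "only" and "open" are said of these compounds alone.

This piece follows one change in a small set of compounds that share a core. In an ADME assay on LLC-MK2 cells (Macaca mulatta) for cytotoxicity, read by spectrophotometry and crystal violet staining, with a stated time of 4 days (a higher number here means that more compound is tolerated, a lower number that less compound is tolerated), compound 1 `CC(C)n1ncc2c(C(=O)Nc3c(F)cc(F)cc3F)cc(-c3cccs3)nc21` is reported only as a limit of the assay, > 200000 nM. Compound 2 `CC(C)n1ncc2c(C(=O)Nc3cccc(F)c3F)cc(-c3cccs3)nc21`, which carries 2,3-difluorophenyl in place of 2,4,6-trifluorophenyl on an amide-type nitrogen, gives a real number in this assay, 75000 nM; that is an at least 2.6-fold lower number from compound 1 to compound 2 (0.42 log units; beyond the scatter). Compound 3 `CC(C)n1ncc2c(C(=O)Nc3ccc(F)cc3)cc(-c3ccsc3)nc21` is likewise reported only as a limit in this assay, > 200000 nM. So compound 3 stands at the boundary of the measurement, (the limit of > 200000 nM in this assay, at which 2 of the 3 values shown sit), with only compound 2 giving a number.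

Compound 4 `CC(C)n1ncc2c(C(=O)Nc3ccc(F)cc3)cc(-c3cccs3)nc21` differs from compound 3 in one place: thiophen-2-yl in place of thiophen-3-yl on an aromatic carbon. Among the compounds with values here, no measured step touches the thiophene; the only measured step, an at least 2.6-fold lower number from compound 1 to compound 2 (0.42 log units; beyond the scatter), changes the group on the amide-type nitrogen, and its size cannot be carried over to this change. An expectation rests instead on the observation that two of three values sit at the boundary, (the limit of > 200000 nM in this assay, at which 2 of the 3 values shown sit). The expected step is therefore small: a number no higher from compound 3 to compound 4 (the limit leaves the size open). Compound 4 is estimated to give about 200000 nM in this assay, between 75000 nM and 500000 nM, and most likely it too is reported only as a limit.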

Compound 4, half-maximal cytotoxic concentration: > 200000 nM
Compound 4 was reported as a limit (the forecaster's own chance of this, stated with the estimate: 65%); the middle value sits exactly at the limit.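

In this assay compound 4 is reported only as a limit (> 200000 nM), so with thiophen-2-yl on the aromatic carbon next to the ring nitrogen, 4-fluorophenyl on the amide-type nitrogen ends at the limit, as 2,4,6-trifluorophenyl does in compound 1. Replacing 2,3-difluorophenyl with 4-fluorophenyl gives an at least 2.6-fold higher number from compound 2 to compound 4 (0.42 log units; beyond the scatter) and so adds a second readable step, which leaves compound 2 as the only compound shown with a real number. The steps from compound 3 to compound 4 and from compound 1 to compound 4 cannot be read, because both ends of each are limits: the limit of > 200000 nM in this assay, at which 3 of the 4 values shown sit.

On these data alone, whether thiophen-2-yl and thiophen-3-yl differ at all in this assay stays open, and a readable comparison would need a pair of compounds that differ only in the thiophene and both give real numbers. Also open, as far as these compounds go, is how the number would respond if an amine or a carboxylic acid took the place of the thiophene on this aromatic carbon.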